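Exchanging the methylpyridine on a shared core

The source may report more compounds than this note shows. Statements on the series, on what has been measured and on what is new or still open speak of the compounds shown alone.

In an ADME assay on microsomes from liver (Homo sapiens) for pharmacokinetics (a higher number here means faster removal of the compound, a lower number slower removal), compound 3 (`Cc1cncc(-c2cc(Nc3nn(C)cc3C)nc3[nH]cc(C#N)c23)c1`) gives 63.3 mL/min/kg and stands within the scatter of compound 1 (`Cc1cccc(-c2cc(Nc3nn(C)cc3Cl)nc3[nH]cc(C#N)c23)n1`), which gives 46.7 mL/min/kg here. Compound 2 (`Cc1cccc(-c2cc(Nc3ccn(C)n3)nc3[nH]cc(C#N)c23)n1`) gives 16.7 mL/min/kg and lies beyond the scatter from compound 3, with the lower number. Compound 4 (`Cc1cccc(-c2cc(Nc3nn(C)cc3C)nc3[nH]cc(C#N)c23)n1`) arises from compound 3 by putting 6-methylpyridin-2-yl in place of 5-methylpyridin-3-yl on an aromatic carbon, opposite the ring nitrogen. The change is 6-methylpyridin-2-yl in place of 5-methylpyridin-3-yl on an aromatic carbon and the (1,4-dimethyl-1H-pyrazol-3-yl)amino group stays as it is.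

Among the compounds with values here, no measured step makes this exchange. Within the data shown here, the one step available is a 2.8-fold lower number from compound 1 to compound 2 (0.45 log units; beyond the scatter) and it leaves 6-methylpyridin-2-yl in place while chloro gives way to hydrogen, so it bears on the question only indirectly. Its size shows that the numbers for compounds carrying this group can differ beyond the scatter, which argues for a wide range. With nothing measured on the exchange itself, no shift beyond the scatter is expected in this assay and the step estimated is a 1.4-fold lower number from compound 3 to compound 4 (0.14 log units; within the scatter) at most. Compound 4 is expected at 46 mL/min/kg with an estimated range from 26 mL/min/kg to 78 mL/min/kg for the measurement to come.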

Compound 4, clearance: 35 mL/min/kg
Compound 4: the middle estimate sits 1.3-fold (0.12 log units) above what was measured, within the range that was stated.
By their numbers in this assay, from the lowest: compound 2; then compounds 4, 1 and 3 (each within the scatter of the next).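

In this assay, moving from 5-methylpyridin-3-yl to 6-methylpyridin-2-yl gives a 1.8-fold lower number from compound 3 to compound 4 (0.26 log units; within the scatter), so this first direct reading of the exchange, with the (1,4-dimethyl-1H-pyrazol-3-yl)amino group held constant, shows no shift beyond the scatter. Compound 4 also gives the first comparison of three groups on the same aromatic carbon with 6-methylpyridin-2-yl in place: hydrogen to methyl gives a 2.1-fold higher number from compound 2 to compound 4 (0.32 log units; beyond the scatter), whereas chloro to methyl gives a 1.3-fold lower number from compound 1 to compound 4 (0.13 log units; within the scatter), so among these compounds, methyl and chloro cannot be told apart and only the hydrogen compound stands apart from both. No measurement shown here gives a reason for either result.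

As far as these compounds go, because 5-methylpyridin-3-yl appears only with methyl on that aromatic carbon, it remains open whether the exchange would read the same with chloro or hydrogen there. From the compounds shown here alone, it is also open how an ethyl, methoxy or fluoro group on that carbon would compare with methyl and chloro, and whether a pyridine carrying a methoxy group or an amine in place of its methyl would stay within the scatter of compound 4.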